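The source may report more compounds than this note shows. Statements on the series, on what has been measured and on what is new or still open speak of the compounds shown alone.

In a functional assay on MCF7 cells (Homo sapiens) for inhibition, with a stated time of 96 h (on this read-out lower numbers stand for stronger inhibition and higher numbers for weaker inhibition), compound 3 `COc1cc(C(=O)c2cn(-c3cccc(C)c3)cc2-c2ccoc2)cc(OC)c1OC` gives 21 nM, level with compound 2 `COc1cc(C(=O)c2cn(-c3cccc(C)c3)cc2-c2ccco2)cc(OC)c1OC` at 23 nM, while compound 1 `COc1cc(C(=O)c2cn(-c3cccc(C)c3)cc2-c2ccsc2)cc(OC)c1OC` reads higher at 65 nM. Compound 4 `COc1cc(C(=O)c2cn(-c3cccc(C)c3)cc2-c2nccs2)cc(OC)c1OC` carries 1,3-thiazol-2-yl in place of furan-3-yl on an aromatic carbon. Going by the values given here, three measured steps bear on this swap. Exchanging one furan form for the other gave a 1.1-fold lower number from compound 2 to compound 3 (0.04 log units; within the scatter), a change within the scatter. Exchanging thiophen-3-yl, the only sulfur-bearing ring measured so far, for a furan gave a 2.8-fold lower number from compound 1 to compound 2 (0.45 log units; beyond the scatter) and a 3.1-fold lower number from compound 1 to compound 3 (0.49 log units; beyond the scatter), both modest. As far as these compounds go, the 1,3-thiazol-2-yl group also contains sulfur, so a modest move to a higher number is expected, though this ring itself is untested. The expected step is a 2.9-fold higher number from compound 3 to compound 4 (0.46 log units; beyond the scatter). For compound 4, the estimated value is 60 nM, within an expected range of 20 nM to 180 nM.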

Compound 4, half-maximal inhibitory concentration: 20 nM
Compound 4: middle estimate off by 3.0-fold (0.48 log units), on the high side; the range from low to high includes it.
By their numbers in this assay, from the lowest: compounds 4, 3 and 2 (each within the scatter of the next); then compound 1.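

Sulfur in the ring does not by itself bring a higher number at this position: the 1,3-thiazol-2-yl group shows a 1.1-fold lower number from compound 3 to compound 4 (0.02 log units; within the scatter) and a 1.2-fold lower number from compound 2 to compound 4 (0.06 log units; within the scatter), so it sits level with both furans. Against thiophen-3-yl, the same group gives a 3.3-fold lower number from compound 1 to compound 4 (0.51 log units; beyond the scatter), which leaves compound 1 as the only one set apart among these rings. Nothing measured here explains why these two sulfur-bearing rings differ. As far as these compounds go, all four compounds carry a five-membered aromatic ring at this position, so how an amine or a carboxylic acid would behave there remains open.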